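Indole Acrylonitrile Sulfones: Dropping a Methoxy from the Fused Ring

This account rests on a few compounds, and the source may have more. Where it says the series, first, only, none or still open, it means among the compounds named here.

Measured compounds:
compound 1 `N#C/C(=C\c1c(-c2ccccc2)[nH]c2ccccc12)C(N)=O`, 6000 nM
compound 2 `N#C/C(=C\c1c[nH]c2ccccc12)S(=O)(=O)c1ccccc1`, > 100000 nM
compound 3 `COc1ccc(-c2[nH]c3ccc(OC)cc3c2/C=C(\C#N)S(=O)(=O)c2ccccc2)cc1`, 200 nM

Of the compounds shown here, three have been tested in a functional assay on MT4 cells (Homo sapiens) for antiproliferative activity, read by MTT assay, with a stated time of 96 h; on this read-out lower numbers stand for an effect already at smaller amounts and higher numbers for an effect only at larger amounts of compound. Compound 1, carrying a phenyl on the shared core together with a cyanoacrylamide arm, gives 6000 nM. For compound 2 the result is only a limit of the assay, > 100000 nM, which is the limit of > 100000 nM in this assay, at which 1 of the 3 values shown sits. Compound 3, bearing two methoxy groups and the sulfone arm, gives 200 nM and stands at the lowest number among the two numerical values; the nearest, compound 1, sits a long way higher, well beyond the scatter.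

The next compound, compound 4 `COc1ccc(-c2[nH]c3ccccc3c2/C=C(\C#N)S(=O)(=O)c2ccccc2)cc1`, is not yet measured. It differs from compound 3 in one place: hydrogen in place of methoxy on an aromatic carbon. The methoxy on the aromatic phenyl of compound 3 remains; the one on the fused ring is lost.

Within the data shown here, since no pair of measured compounds differs in exactly one place, no measured step can guide the size of this change. The author expects the step of a 3.0-fold higher number from compound 3 to compound 4 (0.48 log units; beyond the scatter) to be a modest move toward higher numbers, possibly within the scatter. Compound 4 is therefore estimated at 600 nM, with a range from 150 nM to 3000 nM.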

Compound 4, half-maximal effective concentration: 200 nM
For compound 4 the middle estimate is 3.0-fold (0.48 log units) above the measured one; low and high end bracket the measured number.
By their numbers in this assay, from the lowest: compounds 3 and 4 (each within the scatter of the next); then compound 1. At a limit, above all of these: compound 2.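

In this assay, the methoxy on the fused ring can be exchanged for hydrogen with no change at the digits printed from compound 3 to compound 4 (within the scatter), so with the 4-methoxyphenyl in place, this position shows no dependence on the methoxy group. The second single change behaves very differently: 4-methoxyphenyl in place of hydrogen on an aromatic carbon gives an at least 500-fold lower number from compound 2 to compound 4 (2.69 log units; beyond the scatter), the first measured sign that this substituent, and not the methoxy on the fused ring, accompanies the large move among these sulfones. The size of that step is a bound and not an exact figure, as the value of compound 2 is a limit of the assay: the limit of > 100000 nM in this assay, at which 1 of the 4 values shown sits.

As far as these compounds go, what remains open is whether the fused-ring position accepts anything other than hydrogen and methoxy, such as fluorine, an amine or a carboxylic acid, without a change in the number. From the compounds shown here alone, it is also open how much of the large step belongs to the phenyl ring itself and how much to its methoxy, which a plain phenyl or a 4-hydroxyphenyl on the sulfone series would separate.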